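Nitro to methoxy on the sulfonyl-bearing aryl ring

A few compounds are considered here, and "the series" means these few. Any claim that something is new, unique, unknown or untested is made for them only; others in the source may bear on it.

In a functional assay on A549 cells (Homo sapiens) for cytotoxicity, read by crystal violet staining, with a stated time of 3 days (on this read-out lower numbers stand for stronger inhibition and higher numbers for weaker inhibition), compound 2 `COc1cc2c(cc1OC)C(/C(C)=N/NC(N)=S)N(S(=O)(=O)c1ccc([N+](=O)[O-])cc1)CC2` gives only a limit, > 50 ug/mL. Compound 1 `COc1cc2c(cc1OC)C(/C(C)=N/NC(N)=S)N(S(=O)(=O)c1ccc(C)cc1)CC2` likewise sits at a limit in this assay, > 50 ug/mL. The step that the two limits leave unreadable from compound 1 to compound 2 stays unreadable since (the limit of > 50 ug/mL in this assay, at which 2 of the 2 values shown sit). Compound 3 `COc1ccc(S(=O)(=O)N2CCc3cc(OC)c(OC)cc3C2/C(C)=N/NC(N)=S)cc1` carries methoxy in place of nitro on an aromatic carbon. The single measured step bears on this change only through its unreadability; no shown value falls below the limit, so no direction can be drawn from it. The expected step is a step that the limit leaves unreadable from compound 2 to compound 3, a limit again being the likelier outcome. Compound 3 is therefore estimated at 60 ug/mL, between 25 ug/mL and 200 ug/mL.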

Compound 3, half-maximal inhibitory concentration: > 50 ug/mL
Compound 3 ended at the assay's limit; the forecaster's own chance of this, stated with the estimate: 75%; the middle value does not contradict the limit.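

No step can be read among compound 1, compound 2 and compound 3, since all three stand at a limit: the limit of > 50 ug/mL in this assay, at which 3 of the 3 values shown sit.

The compounds shown leave open whether methyl, nitro and methoxy on this aromatic ring differ at all.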